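Substituent survey on the fused-ring position in compound 3

A few compounds are considered here, and "the series" means these few. Any claim that something is new, unique, unknown or untested is made for them only; others in the source may bear on it.

Measured compounds:
compound 1 `Cn1c(CN2CCN(c3nc(Cl)ccc3C(F)(F)F)CC2)nc2cc(C(F)(F)F)ccc21` gives 2000 nM in an assay on CHO cells with metabotropic glutamate receptor 2 (Homo sapiens) as the target, read by FLIPR; on this read-out lower numbers stand for an effect already at smaller amounts and higher numbers for an effect only at larger amounts of compound
compound 2 `COc1ccc2c(c1)nc(CN1CCN(c3nc(Cl)ccc3C(F)(F)F)CC1)n2C` gives 251 nM in this assay
compound 3 `Cn1c(CN2CCN(c3nc(Cl)ccc3C(F)(F)F)CC2)nc2cc(F)ccc21` gives 200 nM in this assay

Compound 3 holds the lowest number of the three in this assay, though its gap to compound 2 lies within the scatter; only compound 1 is clearly apart, as seen in a 10-fold lower number from compound 1 to compound 3 (1.00 log units; beyond the scatter) and an 8.0-fold lower number from compound 1 to compound 2 (0.90 log units; beyond the scatter).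

Compound 4 `Cn1c(CN2CCN(c3nc(Cl)ccc3C(F)(F)F)CC2)nc2cc(C#N)ccc21` carries cyano in place of fluoro on an aromatic carbon. Going by the values given here, no measured step covers a cyano group here. The two steps that bear on the position are a 10-fold lower number from compound 1 to compound 3 (1.00 log units; beyond the scatter) and an 8.0-fold lower number from compound 1 to compound 2 (0.90 log units; beyond the scatter), both modest, while a 1.3-fold lower number from compound 2 to compound 3 (0.10 log units; within the scatter) is within the scatter, so fluoro and methoxy behave alike and trifluoromethyl stands out. Going by these compounds, a cyano group is untested, so a step in this assay is expected to be small to modest, more likely toward a higher number. Compound 4 is estimated at 400 nM, range 150 nM to 1200 nM, a step of a 2.0-fold higher number from compound 3 to compound 4 (0.30 log units; within the scatter).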

Compound 4, half-maximal effective concentration: 50.1 nM
For compound 4 the middle estimate is 8.0-fold (0.90 log units) above the measured one, outside the stated range (below it).
By their numbers in this assay, from the lowest: compound 4; then compounds 3 and 2 (each within the scatter of the next); then compound 1.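

In this assay, going by these compounds alone, this position separates the groups more sharply than the earlier compounds showed: cyano gives a 4.0-fold lower number from compound 3 to compound 4 (0.60 log units; beyond the scatter) and a 5.0-fold lower number from compound 2 to compound 4 (0.70 log units; beyond the scatter), so fluoro and methoxy no longer mark the low end. Across the four groups at this aromatic carbon, the span widens to a 40-fold lower number from compound 1 to compound 4 (1.60 log units; beyond the scatter), with cyano and trifluoromethyl at the two ends. No measured evidence accounts for the cyano result.

Going by these compounds, whether an amine, a carboxylic acid or an amide at this position would fall below or above cyano stays open. Also open, on these data alone, is whether the cyano step carries over to other positions on the shared core.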